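The source may hold more compounds than are shown below. What is called first, only, known or untested is meant among the compounds shown, and "the series" means these compounds.

Measured compounds in an ADME assay on LLC-PK1 cells (Sus scrofa) for permeability; on this read-out lower numbers stand for lower permeability and higher numbers for higher permeability:

Compound 1 `COc1ccccc1C(=O)NC(=O)Nc1ccc(-c2nccs2)c(C(F)(F)F)c1`: 12 10^-6 cm/s
Compound 2 `COc1ccccc1C(=O)NC(=O)Nc1ccc(OCC(F)(F)F)c(C(F)(F)F)c1`: only a limit, < 1 10^-6 cm/s
Compound 3 `COc1ccccc1C(=O)NC(=O)Nc1ccc(N2CCCCC2)c(C(F)(F)F)c1`: only a limit, < 1 10^-6 cm/s

Compound 3 stands at the floor of the numbers shown: in this assay it gives no number, only a limit. The same holds for compound 2, so that two of the three values shown sit at the limit of < 1 10^-6 cm/s in this assay, at which 2 of the 3 values shown sit. Only compound 1 gives a readable number, and the two steps away from it, an at least 12-fold lower number from compound 1 to compound 2 (1.07 log units; beyond the scatter) and an at least 12-fold lower number from compound 1 to compound 3 (1.07 log units; beyond the scatter), are both large and downward. The step between the two limits, a step that the two limits leave unreadable from compound 2 to compound 3, cannot be read.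

The next compound, compound 4 `COc1ccccc1C(=O)NC(=O)Nc1ccc(-c2ccccn2)c(C(F)(F)F)c1`, differs from compound 3 in one place: pyridin-2-yl in place of piperidin-1-yl on an aromatic carbon. Of the measured steps, an at least 12-fold lower number from compound 1 to compound 3 (1.07 log units; beyond the scatter) bears most directly on this change, since compound 1 carries an aromatic ring at the same carbon and sits well above the limit. Reversing the sense of that step, compound 4 is expected to climb back toward the region of compound 1, an estimated step of an at least 8.0-fold higher number from compound 3 to compound 4 (0.90 log units; beyond the scatter). The estimate for compound 4 in this assay is 8 10^-6 cm/s, with a range from 2 10^-6 cm/s to 20 10^-6 cm/s.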

Compound 4, apparent permeability: 7.4 10^-6 cm/s
Estimate against measurement, compound 4: 1.1-fold (0.03 log units) above; low and high end bracket the measured number.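

In this assay, piperidin-1-yl and pyridin-2-yl match in heavy atoms, ring size, hetero atom, hydrogen-bond donors and acceptors and net charge, and differ in whether the ring is aromatic, yet the swap gives an at least 7.4-fold higher number from compound 3 to compound 4 (0.86 log units; beyond the scatter). Against 2,2,2-trifluoroethoxy the result is an at least 7.4-fold higher number from compound 2 to compound 4 (0.86 log units; beyond the scatter), while a 1.6-fold lower number from compound 1 to compound 4 (0.21 log units; within the scatter) leaves pyridin-2-yl and 1,3-thiazol-2-yl not told apart, so two different aromatic rings at this carbon read alike. Among these four compounds none goes against the pattern, as the two groups without an aromatic ring, in compound 2 and compound 3, each leave a limit and not a number: the limit of < 1 10^-6 cm/s in this assay, at which 2 of the 4 values shown sit.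

Going by these compounds, how far under that limit compound 2 and compound 3 lie stays unknown, so the step between them cannot be read and the steps up to compound 4 give only a lower bound on the true size. On these data alone, whether the pattern holds for a plain phenyl ring, a pyridin-3-yl ring, or a non-aromatic group such as morpholin-4-yl or dimethylamino at the same carbon stays open.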